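This account rests on a few compounds, and the source may have more. Where it says the series, first, only, none or still open, it means among the compounds named here.

Compound 1 `COc1ccc(S(=O)(=O)N(CC(N)=O)c2ccc(N(CC(N)=O)S(=O)(=O)c3ccc(SCCN=C=S)cc3)c3ccccc23)cc1` gave > 10000 nM.
Compound 2 `COc1ccc(S(=O)(=O)N(CC(N)=O)c2ccc(N(CC(N)=O)S(=O)(=O)c3ccc(SCCOCCN=C=S)cc3)c3ccccc23)cc1` gave > 10000 nM.
Compound 3 `COc1ccc(S(=O)(=O)N(CC(N)=O)c2ccc(N(CC(N)=O)S(=O)(=O)c3ccc([S+]([O-])CCOCCN=C=S)cc3)c3ccccc23)cc1` gave > 10000 nM.

All three were read in an ADME assay on cells (Peritoneal macrophage, Mus musculus) for cytotoxicity, read by CCK-8 assay, with a stated time of 24 h; a higher number here means that more compound is tolerated, a lower number that less compound is tolerated. Each of these values is a limit of the assay, not a number. For compound 1 the value is a limit. For compound 2 the value is a limit. For compound 3 the value is a limit as well. Between compound 1 and compound 2 the change is a group of 6 heavy atoms (3 carbon, 1 nitrogen, 1 oxygen, 1 sulfur; no ring) in place of a group of 3 heavy atoms (1 carbon, 1 nitrogen, 1 sulfur; no ring), on a saturated chain carbon, two bonds along the chain from a sulfur, and the step is a step that the two limits leave unreadable from compound 1 to compound 2. The cores of compound 1 and compound 3 differ by a group of 10 heavy atoms (5 carbon, 1 nitrogen, 2 oxygen, 2 sulfur; no ring) in place of a group of 6 heavy atoms (3 carbon, 1 nitrogen, 2 sulfur; no ring), on an aromatic carbon; the step there is a step that the two limits leave unreadable from compound 1 to compound 3, and from compound 2 to compound 3 it is a step that the two limits leave unreadable from compound 2 to compound 3. All of this rests on (the limit of > 10000 nM in this assay, at which 3 of the 3 values shown sit).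

Compound 4 `COc1ccc(S(=O)(=O)N(CC(N)=O)c2ccc(N(CC(N)=O)S(=O)(=O)c3ccc([S+]([O-])CCOCCOCCN=C=S)cc3)c3ccccc23)cc1` has not been measured. From compound 3 it differs by a group of 6 heavy atoms (3 carbon, 1 nitrogen, 1 oxygen, 1 sulfur; no ring) in place of a group of 3 heavy atoms (1 carbon, 1 nitrogen, 1 sulfur; no ring), on a saturated chain carbon, two bonds along the chain from an oxygen on a saturated carbon. This is the same kind of change as that from compound 1 to compound 2, though the place differs: there it sat two bonds along the chain from a sulfur, here two bonds along the chain from an oxygen on a saturated carbon. Beside a step that the two limits leave unreadable from compound 1 to compound 2, the expected step is a step that the limit leaves unreadable from compound 3 to compound 4, since the limit of > 10000 nM in this assay, at which 3 of the 3 values shown sit, holds every value shown. Compound 4 is therefore estimated at 20000 nM in this assay, most likely again only a limit.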

Compound 4, half-maximal cytotoxic concentration: > 10000 nM
Compound 4 gave a limit, no number; the forecaster's own chance of this, stated with the estimate: 85%; the middle value lies beyond the limit too.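

For compound 4 the value in this assay is > 10000 nM, a limit and not a number. No step can be read from compound 3 to compound 4, because both values are limits: the limit of > 10000 nM in this assay, at which 4 of the 4 values shown sit.

The compounds shown leave open at what concentration any of them would become cytotoxic to these cells, and whether the group exchanged between compound 3 and compound 4 would alter that concentration.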